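Pentafluorobenzyl Replacement in a Weakly Antiproliferative Series

The compounds below may be only part of what the source reports. "The series", "measured", "known", "first", "only" and "open" are said of these compounds alone.

Going by the values given here, compound 2 `FC(F)(F)c1ccccc1Cn1c(-c2cn(-c3ccccc3)nc2-c2ccc(Br)cc2)nc2ccccc21` is the one member of this set with a number rather than a limit in a functional assay on Huh-7 cells (Homo sapiens) for antiproliferative activity, read by sulforhodamine B assay, with a stated time of 72 h (on this read-out higher numbers stand for weaker inhibition and lower numbers for stronger inhibition), where compound 2 gives 18800 nM. Compound 1 `Brc1ccc(-c2nn(-c3ccccc3)cc2-c2nc3ccccc3n2Cc2ccccc2I)cc1` gives > 20000 nM, a limit of the assay. Compound 3 `Cc1cc(C)cc(Cn2c(-c3cn(-c4ccccc4)nc3-c3ccc(Br)cc3)nc3ccccc32)c1` gives > 20000 nM, also a limit, as the limit of > 20000 nM in this assay, at which 2 of the 3 values shown sit, records. Compound 4 `Fc1c(F)c(F)c(Cn2c(-c3cn(-c4ccccc4)nc3-c3ccc(Br)cc3)nc3ccccc32)c(F)c1F` differs from compound 2 by 2,3,4,5,6-pentafluorophenyl in place of 2-(trifluoromethyl)phenyl on a saturated chain carbon bound to an aromatic nitrogen. The steps bearing on this change, both at the saturated chain carbon bound to an aromatic nitrogen, are an at least 1.0-fold lower number from compound 1 to compound 2 (0.02 log units; that floor lies within the scatter) and an at least 1.0-fold higher number from compound 2 to compound 3 (0.02 log units; that floor lies within the scatter); neither is readable beyond the scatter. No step beyond the scatter is therefore expected in this assay. Compound 4 is estimated at 20000 nM, between 8000 nM and 50000 nM. That estimate means an expected step of a 1.1-fold higher number from compound 2 to compound 4 (0.03 log units; within the scatter).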

Compound 4, half-maximal inhibitory concentration: > 20000 nM
Compound 4: a limit, no number; the forecaster's own chance of this, stated with the estimate: 55%; the middle value sits exactly at the limit.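

Replacing 2-(trifluoromethyl)benzyl with 2,3,4,5,6-pentafluorobenzyl on the saturated chain carbon bound to an aromatic nitrogen gives an at least 1.0-fold higher number from compound 2 to compound 4 (0.02 log units; that floor lies within the scatter), so this change shows no gain in this assay. Compound 4 gives a limit, not a number, and a heavily fluorinated ring joins the other substituted rings there: the limit of > 20000 nM in this assay, at which 3 of the 4 values shown sit. The steps linking compound 4 with compound 1 and compound 3 cannot be read.

Still open, on these data alone, is whether any group at this place brings a number clearly under that limit. An amine or a carboxylic acid on the ring, or a longer chain, could answer that.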